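A few compounds are considered here, and "the series" means these few. Any claim that something is new, unique, unknown or untested is made for them only; others in the source may bear on it.

Of the compounds shown here, three have been tested so far in a functional assay on KYSE-450 cells (Homo sapiens) for inhibition, read by CCK-8 assay, with a stated time of 48 h; a higher number here means a weaker inhibitor, a lower number a stronger inhibitor. Compound 1 (`COc1ccc(CN(C(=O)CSC(=S)N2CCCc3cc(OC)ccc32)c2cc(OC)c(OC)c(OC)c2)cc1`) gives 5530 nM there, compound 2 (`COc1ccc(CN(C(=O)CN2CCN(C(C)=O)CC2)c2cc(OC)c(OC)c(OC)c2)cc1`) gives 10800 nM there, and compound 3 (`COc1cc(N(Cc2ccc(Cl)cc2)C(=O)CSC(=S)N2CCN(C(=O)OC(C)(C)C)CC2)cc(OC)c1OC`) gives 11900 nM there. Compound 3 lies within the usual scatter of compound 2, and it is weaker than compound 1 by more than that scatter.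

Compound 4 (`COc1ccc(CN(C(=O)CSC(=S)N2CCN(C(=O)OC(C)(C)C)CC2)c2cc(OC)c(OC)c(OC)c2)cc1F`) has 3-fluoro-4-methoxyphenyl in place of 4-chlorophenyl on a saturated chain carbon bound to an amide-type nitrogen. Among the compounds with values here, no measured pair differs in only one place, so the data give no direct guide to this change. A small step towards a lower number is expected, probably not beyond the scatter. The expected change is a 1.5-fold lower number from compound 3 to compound 4 (0.17 log units; within the scatter) in this estimate. Compound 4 is estimated at 8000 nM, with an expected range from 3500 nM to 18000 nM in this assay.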

Compound 4, half-maximal inhibitory concentration: 2410 nM
Estimate against measurement, compound 4: 3.3-fold (0.52 log units) above; measured number below the stated range.
By their numbers in this assay, from the lowest: compound 4; then compounds 1, 2 and 3 (each within the scatter of the next, the first and the last beyond it).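

Replacing 4-chlorobenzyl with 3-fluoro-4-methoxybenzyl, with the rest of the molecule unchanged, gives a 4.9-fold lower number from compound 3 to compound 4 (0.69 log units; beyond the scatter) in this assay as the read-out. Within the data shown here, this is the first single-place comparison here, and it shows that the aromatic group on a saturated chain carbon bound to an amide-type nitrogen can shift potency beyond the scatter by itself. Nothing available explains the stronger inhibition.

Whether the fluorine, the methoxy group or the pair accounts for the step remains open. So does the outcome of putting an amine or a carboxylic acid on this phenyl ring.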